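Sulfamoyl nitrogen substitution in the amidine series

A few compounds are considered here, and "the series" means these few. Any claim that something is new, unique, unknown or untested is made for them only; others in the source may bear on it.

Measured so far in an assay on isolated protein for binding affinity to serine protease 1 (Homo sapiens); a higher number here means a weaker inhibitor, a lower number a stronger inhibitor:
compound 1, `N=C(N)c1ccc2ncn(CC(=O)Nc3ccc(-c4ccccc4)cc3)c2c1`: 480 nM
compound 2, `CNS(=O)(=O)c1ccccc1-c1ccc(NC(=O)Cc2c[nH]c3ccc(C(=N)N)cc23)cc1`: 120 nM
compound 3, `CN(C)S(=O)(=O)c1ccccc1-c1ccc(NC(=O)Cc2c[nH]c3ccc(C(=N)N)cc23)cc1`: 390 nM

Compound 3 stands second highest of the three numbers in this assay. Compound 1 sits within the scatter of it at 480 nM, whereas compound 2, at 120 nM, lies outside the scatter of compound 3. Compound 4, `CCCNS(=O)(=O)c1ccccc1-c1ccc(NC(=O)Cc2c[nH]c3ccc(C(=N)N)cc23)cc1`, differs from compound 3 by propylamino in place of dimethylamino on a sulfonyl sulfur. Going by the values given here, one measured step bears on this change: a 3.3-fold higher number from compound 2 to compound 3 (0.51 log units; beyond the scatter), in which a methyl replaced the hydrogen on the sulfonamide nitrogen and the number rose. Among the compounds with values here, compound 4 puts a hydrogen back on that nitrogen and carries a propylamino group in place of dimethylamino, so a reversal of some or all of that step is expected, with the uncertainty that no measured pair shows a propyl chain on this nitrogen. Compound 4 is therefore expected to reach 180 nM, within 80 nM to 400 nM. The expected step is a 2.2-fold lower number from compound 3 to compound 4 (0.34 log units; beyond the scatter), towards a lower number than compound 3.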

Compound 4, inhibition constant: 180 nM
The estimate for compound 4 equals the measured number at the digits printed; measured number inside the range.
By their numbers in this assay, from the lowest: compounds 2 and 4 (each within the scatter of the next); then compounds 3 and 1 (each within the scatter of the next).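

In this assay, the change from dimethylsulfamoyl to propylsulfamoyl gives a 2.2-fold lower number from compound 3 to compound 4 (0.34 log units; beyond the scatter), so among the three sulfonamides, compound 3, the only one without a hydrogen on the sulfonamide nitrogen, carries the highest number. Ethyl in place of hydrogen on the saturated chain carbon bound to the sulfonamide nitrogen gives a 1.5-fold higher number from compound 2 to compound 4 (0.18 log units; within the scatter), so compound 2 and compound 4 cannot be told apart and this position tolerates the propyl chain as well as the methyl group. Nothing at hand accounts for these differences.

On these data alone, whether the hydrogen on the nitrogen or the shape of the substituent governs the number remains open, and diethylamino on the sulfonyl sulfur would bear on that. Also open, as far as these compounds go, are the unsubstituted sulfamoyl group, a longer chain such as butyl, and a branched isopropyl group on the same nitrogen.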